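Diethylamino for pentylamino on the shared core

A few compounds are considered here, and "the series" means these few. Any claim that something is new, unique, unknown or untested is made for them only; others in the source may bear on it.

In an ADME assay on MT4 cells (Homo sapiens) for cytotoxicity, read by MTT assay (on this read-out higher numbers stand for lower toxicity in this test and lower numbers for higher toxicity in this test), compound 1 `CC(C)NC(=O)C1C(=O)N(O)C(=O)c2ccccc21` gives 163000 nM and compound 2 `CCCCCNC(=O)C1C(=O)N(O)C(=O)c2ccccc21` gives 130000 nM so compound 2 stands within the scatter of compound 1. Compound 3 `CCN(CC)C(=O)C1C(=O)N(O)C(=O)c2ccccc21` is still unmeasured and differs from compound 2 by diethylamino in place of pentylamino on a carbonyl carbon. For the measured compounds named here, the only measured step that bears on this is a 1.3-fold lower number from compound 1 to compound 2 (0.10 log units; within the scatter) for pentyl in place of isopropyl on an amide-type nitrogen, so no step beyond the scatter is expected in this assay and no direction is favoured. Going by the values given here, no measured compound carries diethylamino, which leaves this expectation resting on a single small step. The estimated move is a 1.1-fold higher number from compound 2 to compound 3 (0.03 log units; within the scatter) and remains tentative. For compound 3 the expected value is 140000 nM (estimated range 70000 nM to 280000 nM).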

Compound 3, half-maximal cytotoxic concentration: 28000 nM
Estimate against measurement, compound 3: 5.0-fold (0.70 log units) above; the measured number lies below the stated range.
By their numbers in this assay, from the lowest: compound 3; then compounds 2 and 1 (each within the scatter of the next).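

Read in this assay, the change to diethylamino on the carbonyl carbon gives a 4.6-fold lower number from compound 2 to compound 3 (0.67 log units; beyond the scatter) and a 5.8-fold lower number from compound 1 to compound 3 (0.77 log units; beyond the scatter) and so moves towards higher toxicity in this test, which pentyl in place of isopropyl on the amide-type nitrogen did not do. This position therefore responds to at least one change, and the one that does so replaces pentylamino, with 1 hydrogen-bond donor, by diethylamino, with 0 hydrogen-bond donors. Nothing at hand gives a reason for this shift.

On these data alone, whether the shift goes with the missing amide hydrogen or with something else about diethylamino stays open. Ethylamino, which keeps the amide hydrogen, and piperidine, a ring amine that lacks it, would separate the two readings on the shared core.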